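The source may hold more compounds than are shown below. What is called first, only, known or untested is meant among the compounds shown, and "the series" means these compounds.

Of the compounds shown here, two of the same shared core have so far been tested in a functional assay on MCF7 cells (Homo sapiens) for cytotoxicity, read by MTT assay, with a stated time of 72 h; a lower number here means a stronger inhibitor, a higher number a weaker inhibitor. Compound 1, `COc1cccc(/C=C2\CCC/C(=C\c3cccc(O)c3)C2=O)c1OC`, gives 8800 nM in this assay. Compound 2, `COc1ccc(/C=C2\CCC/C(=C\c3ccc(Br)cc3)C2=O)cc1OC`, gives 6900 nM in this assay. Compound 2 thus shows the smaller of the two numbers, but the gap to compound 1 lies within the usual scatter of repeated measurements, so the two compounds cannot be told apart on these data.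

The next compound, compound 3, `COc1cc(/C=C2\CCC/C(=C\c3ccc(OC)c(OC)c3)C2=O)ccc1O`, has not yet been measured in this assay. It differs from compound 2 in one place: 4-hydroxy-3-methoxyphenyl in place of 4-bromophenyl on a double-bonded chain carbon bound to a double-bonded ring carbon. Among the measured compounds shown here, there is no measured pair that shows what this kind of exchange does in this assay, so the expectation has to rest on the two numbers at hand, which sit close together.

Compound 3 is therefore expected to land near compound 2, with the estimated step from compound 2 to compound 3 being a 1.2-fold lower number from compound 2 to compound 3 (0.06 log units; within the scatter), a step not expected to go beyond the scatter in either direction. For compound 3 the estimate in this assay is 6000 nM, within a range from 2500 nM to 15000 nM.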

Compound 3, half-maximal inhibitory concentration: 7900 nM
For compound 3 the middle estimate is 1.3-fold (0.12 log units) below the measured one; the measured number falls inside the stated range.
By their numbers in this assay, from the lowest: compounds 2, 3 and 1 (each within the scatter of the next).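

Among the compounds shown here, the step of a 1.1-fold higher number from compound 2 to compound 3 (0.06 log units; within the scatter) in this assay is the first measured for this place on the shared core, a double-bonded chain carbon bound to a double-bonded ring carbon. It shows that 4-bromophenyl can give way to 4-hydroxy-3-methoxyphenyl, going from 7 heavy atoms to 9 and from 0 hydrogen-bond donors and 0 acceptors to 1 donor and 2 acceptors, without a difference that can be told from the scatter. Nothing at hand gives a measured property that could explain why these two groups read alike.

The compounds shown leave open whether a group of another kind at this place, such as an amine, a carboxylic acid or a longer chain in place of the aromatic ring, would give a number beyond the scatter. They also do not separate the hydroxy group from the methoxy group of 4-hydroxy-3-methoxyphenyl, which enter together in this single exchange.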